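Chloro for Amino on the Benzyl Ring: Cytotoxicity Outlook

The source may report more compounds than this note shows. Statements on the series, on what has been measured and on what is new or still open speak of the compounds shown alone.

Two measured compounds share one core and differ in a single group on the benzyl ring. Compound 1 `COC(=O)c1ccc(NCc2cncn2Cc2cccc(C)c2)cc1-c1ccccc1` carries a methyl there. In a toxicity assay on NIH3T3 cells (Mus musculus) for cytotoxicity, read by resazurin assay (a lower number here means that less compound is needed, a higher number that more compound is needed for the effect), compound 1 gives > 10000 nM, which is a limit of the assay and not a number. Compound 2 `COC(=O)c1ccc(NCc2cncn2Cc2cccc(N)c2)cc1-c1ccccc1` carries an amino in the same place. In this assay compound 2 gives > 10000 nM, again a limit. The step that the two limits leave unreadable from compound 1 to compound 2 therefore cannot be read in size, since (the limit of > 10000 nM in this assay, at which 2 of the 2 values shown sit). Where compound 2 stands is thus known only as a limit, not as a number.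

Compound 3 `COC(=O)c1ccc(NCc2cncn2Cc2cccc(Cl)c2)cc1-c1ccccc1` is the partner not yet measured. The change from compound 2 to compound 3 is chloro in place of amino on an aromatic carbon. Among the measured compounds shown here, only one measured step bears on this change, and its size is not readable, because both measured compounds sit at the limit of > 10000 nM in this assay, at which 2 of the 2 values shown sit. With nothing to suggest movement, the expectation is no step beyond the scatter. The estimated step is a step that the limit leaves unreadable from compound 2 to compound 3, within the scatter. Compound 3 is expected to give 15000 nM in this assay, with the range 5000 nM to 50000 nM, and most likely again only a limit.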

Compound 3, half-maximal effective concentration: > 10000 nM
Compound 3: no number, only a limit (the forecaster's own chance of this, stated with the estimate: 75%); the middle value lies beyond the limit too.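

In this assay compound 3 gives > 10000 nM, which is a limit of the assay and not a number. No step among compound 1, compound 2 and compound 3 can be read in size, because all three sit at the same limit: the limit of > 10000 nM in this assay, at which 3 of the 3 values shown sit.

The compounds shown leave open at what concentration, if any, each of the three reaches its effect in this assay.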